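This account rests on a few compounds, and the source may have more. Where it says the series, first, only, none or still open, it means among the compounds named here.

Compound 1 `CC(=O)Nc1ccc(S(=O)(=O)NNC(=O)c2cccnc2Nc2ccc(Cl)cc2)cc1` in a functional assay on Malme-3M cells (Homo sapiens) for antiproliferative activity (on this read-out higher numbers stand for weaker inhibition of growth and lower numbers for stronger inhibition of growth), gives > 100000 nM.
Compound 2 `O=C(NNS(=O)(=O)c1ccc(F)cc1)c1cccnc1Nc1ccc(Cl)cc1Cl` in this assay gives > 100000 nM.

The two measured compounds share a core built around a pyridine carbonyl hydrazide joined to a sulfonyl group, and both come out at the top of the measurable range. For compound 1 the value is a limit of this assay, not a number. For compound 2 the value is likewise a limit. Where compound 1 stands is therefore set by the limit of > 100000 nM in this assay, at which 2 of the 2 values shown sit; no ordering between the two compounds can be read from this.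

The new compound, compound 3 `O=C(NNS(=O)(=O)c1ccc(Cl)cc1Cl)c1cccnc1Nc1ccc(Cl)cc1`, keeps the core of compound 1 and changes only the aryl group on the sulfonyl sulfur: 2,4-dichlorophenyl in place of 4-acetamidophenyl on a sulfonyl sulfur. Among the measured compounds shown here, no step between measured compounds is known, and nothing in the data points to a gain in growth inhibition from such a change; the expected step of a number no higher from compound 1 to compound 3 (the limit leaves the size open) is none beyond the scatter, most likely ending again at the limit. Compound 3 is expected to give 100000 nM, within a range from 30000 nM to 300000 nM.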

Compound 3, concentration for total growth inhibition: 34700 nM
Estimate against measurement, compound 3: 2.9-fold (0.46 log units) above; low and high end bracket the measured number.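

Among the compounds shown here, compound 3 is the first compound here to give a real number instead of a limit, which shows that the aryl group on the sulfonyl sulfur is a place where growth inhibition can change on the shared core. In this assay, 2,4-dichlorophenyl in place of 4-acetamidophenyl gives an at least 2.8-fold lower number from compound 1 to compound 3 (0.45 log units; beyond the scatter), a step beyond the usual scatter. That size is only a minimum because the value for compound 1 is a limit of the assay and not a number: the limit of > 100000 nM in this assay, at which 2 of the 3 values shown sit.

The compounds shown leave open whether the gain comes from the two chlorine atoms that enter or from the loss of the 4-acetamidophenyl group, a question that a plain phenyl or a 4-chlorophenyl on the sulfonyl sulfur would help to settle. They also leave open how far the number can fall at this place, for instance with an amine or a carboxylic acid on that ring, or with a small methyl group directly on the sulfonyl sulfur.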